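Removing the Dimethylamino Group from Compound 2

This account rests on a few compounds, and the source may have more. Where it says the series, first, only, none or still open, it means among the compounds named here.

Compound 1 `CN(C)c1nc(N)sc1C(=O)c1cnc2ccccn12` gives 32% in a functional assay on the whole organism (strain Sprague-Dawley) for inhibition, with Rattus norvegicus as the target, read by paw edema, with stated times of 1 h and 3 h, at a dose of 50 mg/kg by the oral route; a higher number here means more inhibition at the dose given (going by the name of the read-out), a lower number less inhibition. Compound 2 `Cc1ccc2ncc(C(=O)c3sc(N)nc3N(C)C)n2c1` gives 23% in this assay, the second highest of the three numbers, and compound 3 `Cc1cccn2c(C(=O)c3sc(N)nc3-c3ccccc3)cnc12` gives 20%. Among the compounds with values here, the only single-point step known is a number 9 percentage points lower from compound 1 to compound 2 (within the scatter), a methyl in place of hydrogen on an aromatic carbon, and it does not touch the dimethylamino group. Compound 4 `Cc1ccc2ncc(C(=O)c3cnc(N)s3)n2c1` differs from compound 2 by hydrogen in place of dimethylamino on an aromatic carbon. Within the data shown here, no measured step bears on this change; the values of compound 2 and compound 3 lie within the scatter of each other. Compound 4 is therefore expected to show no step beyond the scatter, estimated at 22% with a range of 8% to 38%. That estimate means an expected step of a number 1 percentage points lower from compound 2 to compound 4 (within the scatter).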

Compound 4, a percentage reported as inhibition, in the whole organism at one dose (the size of the read-out at that dose, not a potency): 53%
The estimate for compound 4 lay 31 percentage points below the measured number; measured number outside the range, above it.
By their numbers in this assay, from the lowest: compounds 3, 2 and 1 (each within the scatter of the next, the first and the last beyond it); then compound 4.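

In this assay, the aromatic carbon next to the ring nitrogen proves to be a position that matters: hydrogen in place of dimethylamino gives a number 30 percentage points higher from compound 2 to compound 4 (beyond the scatter), the only step beyond the scatter among those shown. Dimethylamino is therefore not required at this position for inhibition at this dose. Nothing available explains the step.

The compounds shown leave open whether methylamino, a plain amine, methyl or chlorine at this position would give a similar number. They also leave open whether the step would hold without the methyl on the core.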